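The source may hold more compounds than are shown below. What is called first, only, known or untested is meant among the compounds shown, and "the series" means these compounds.

Measured in an ADME assay on L132 cells (Homo sapiens) for cytotoxicity, read by MTT assay, with a stated time of 48 h; on this read-out lower numbers stand for stronger inhibition and higher numbers for weaker inhibition:
- Compound 1 `C/C(=C\CC/C(C)=C/CC[C@@H]1[C@@]2(C)CCC(=O)C(C)(C)[C@H]2CC[C@@]1(C)O)CC/C=C(\C)C(=O)OCc1cn(-c2ccc([N+](=O)[O-])cc2)nn1`: > 150000 nM
- Compound 2 `COc1ccccc1-n1cc(COC(=O)/C(C)=C/CC/C(C)=C/CC/C(C)=C/CC[C@@H]2[C@@]3(C)CCC(=O)C(C)(C)[C@H]3CC[C@@]2(C)O)nn1`: > 150000 nM
- Compound 3 `C/C(=C\CC/C(C)=C/CC[C@@H]1[C@@]2(C)CCC(=O)C(C)(C)[C@H]2CC[C@@]1(C)O)CC/C=C(\C)C(=O)OCc1cn(-c2ccccc2C(F)(F)F)nn1`: > 150000 nM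

Each of these entries is a limit and not a number. The series shares a single reporting ceiling, (the limit of > 150000 nM in this assay, at which 3 of the 3 values shown sit). Compound 3 gives > 150000 nM, which is likewise only a limit, so it stands level with the other two values shown and has no number of its own.

Compound 4 `C/C(=C\CC/C(C)=C/CC[C@@H]1[C@@]2(C)CCC(=O)C(C)(C)[C@H]2CC[C@@]1(C)O)CC/C=C(\C)C(=O)OCc1cn(-c2ccccc2[N+](=O)[O-])nn1` has not yet been measured. It differs from compound 3 as follows: nitro in place of trifluoromethyl on an aromatic carbon. In words, nitro takes the place of trifluoromethyl on an aromatic carbon, ortho to a large group.

Within the data shown here, three measured steps bear on this change: a step that the two limits leave unreadable from compound 2 to compound 3, a step that the two limits leave unreadable from compound 1 to compound 3 and a step that the two limits leave unreadable from compound 1 to compound 2. None of them has a readable size, so they offer no measured effect to carry over. Compound 1 also bears a nitro group on its aryl substituent, and compound 1 gives > 150000 nM, again a limit.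

In this assay, no step beyond the scatter is therefore expected, in either direction. The step expected is a step that the limit leaves unreadable from compound 3 to compound 4. Compound 4 is estimated at 170000 nM, with an expected range from 90000 nM to 320000 nM, and it will most likely be reported only as a limit.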

Compound 4, half-maximal inhibitory concentration: > 150000 nM
Compound 4: only a limit was reported; the forecaster's own chance of this, stated with the estimate: 85%; the middle value is on the limit's open side.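

In this assay, compound 4 is reported only as a limit, as are compound 1, compound 2 and compound 3, so no step between compound 4 and any of them can be read: the limit of > 150000 nM in this assay, at which 4 of the 4 values shown sit.

The compounds shown leave open whether exchanging these aryl substituents changes the read-out at all, and at what concentration any of the four would reach half-maximal inhibition.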